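Chloro for nitro at the limit of the series

The source may hold more compounds than are shown below. What is called first, only, known or untested is meant among the compounds shown, and "the series" means these compounds.

Measured in a functional assay on HepG2 cells (Homo sapiens) for cytotoxicity, read by MTT assay, with a stated time of 72 h (a lower number here means a stronger inhibitor, a higher number a weaker inhibitor), every value a limit:
- Compound 1 `CC(C)n1c(Nc2ccccc2)nc2cnc(Nc3ccc(N4CCN(C)CC4)cc3)nc21`: > 5000 nM
- Compound 2 `Cc1cc(C)cc(-n2c(Nc3ccccc3)nc3cnc(Nc4ccc(N5CCN(C)CC5)cc4)nc32)c1`: > 5000 nM
- Compound 3 `CN1CCN(c2ccc(Nc3ncc4nc(Nc5cccc([N+](=O)[O-])c5)n(C5CCCC5)c4n3)cc2)CC1`: > 5000 nM

Compound 3 gives no number and shares (the limit of > 5000 nM in this assay, at which 3 of the 3 values shown sit).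

Compound 4 `CN1CCN(c2ccc(Nc3ncc4nc(Nc5cccc(Cl)c5)n(C5CCCC5)c4n3)cc2)CC1` differs from compound 3 in one group: chloro in place of nitro on an aromatic carbon. This is chloro in place of nitro on an aromatic carbon, turning 3-nitrophenyl into 3-chlorophenyl.

Going by the values given here, the only measured step is a step that the two limits leave unreadable from compound 1 to compound 2. It places 3,5-dimethylphenyl in place of isopropyl on an aromatic nitrogen, not at the nitro group, and offers no size to carry over. Among the compounds with values here, no measured step therefore bears directly on this change, and no step beyond the scatter is expected in this assay, in either direction.

The expected change is a step that the limit leaves unreadable from compound 3 to compound 4, an estimate that stays within the scatter. Another report as a limit is the likeliest outcome. For compound 4 the estimated value is 6000 nM, with an expected range of 2500 nM to 15000 nM.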

Compound 4, half-maximal inhibitory concentration: 4800 nM
Compound 4: the middle estimate sits 1.3-fold (0.10 log units) above what was measured; low and high end bracket the measured number.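

In this assay, chloro in place of nitro on an aromatic carbon gives an at least 1.0-fold lower number from compound 3 to compound 4 (0.01 log units; that floor lies within the scatter), so the change can be read only as a floor, and that floor does not separate the two compounds. Compound 4 gives 4800 nM, the first actual number in the compounds shown, which gives this position a measured value for the first time. The other compounds shown give only a limit and no number: the limit of > 5000 nM in this assay, at which 3 of the 4 values shown sit.

As far as these compounds go, how far the true value of compound 3 lies from its limit remains unknown, so the full size of this change stays open. Also open, from the compounds shown here alone, is whether an amine, a carboxylic acid or a methoxy group on the same aromatic carbon of the 3-chlorophenyl ring would give a value clearly apart from that of compound 4.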